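The source may report more compounds than this note shows. Statements on the series, on what has been measured and on what is new or still open speak of the compounds shown alone.

In a functional assay on Vero cells (Chlorocebus sabaeus) for inhibition (a lower number here means a stronger inhibitor, a higher number a weaker inhibitor), compound 3 `COc1cc(/C=C/C(=O)c2cccc(NC(=O)C(C)C)c2)ccc1O` gives 3.47 ug/mL, and compound 2 `COc1cc(/C=C/C(=O)c2cccc(N)c2)ccc1O` gives 6.02 ug/mL. These two values lie within the usual scatter of each other, with a 1.7-fold lower number from compound 2 to compound 3 (0.24 log units; within the scatter). Compound 1 `COc1cc(/C=C/C(=O)c2cccc(NC(=O)c3cc(Cl)cc(Cl)c3)c2)ccc1O` reads > 50 ug/mL, which is a limit of the assay and not a number.

The next compound to consider is compound 4 `COc1cc(/C=C/C(=O)c2cccc(NC(=O)c3ccccc3)c2)ccc1O`. It differs from compound 3 at one place: phenyl in place of isopropyl on a carbonyl carbon. In words, this is phenyl in place of isopropyl on a carbonyl carbon.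

The most relevant measured comparison changes the group at that same carbonyl carbon, with an at least 14-fold lower number from compound 1 to compound 3 (1.15 log units; beyond the scatter). Here isopropyl takes the place of 3,5-dichlorophenyl. A second comparison, an at least 8.3-fold lower number from compound 1 to compound 2 (0.91 log units; beyond the scatter), removes the whole (3,5-dichlorophenyl)carbonyl group from the nitrogen. Both steps lead away from compound 1, whereas compound 4 keeps a phenyl ring on the carbonyl but lacks the chloro groups of 3,5-dichlorophenyl. In structure it therefore stands between compound 3 and compound 1, so a move towards a higher number in this assay is expected, though probably only part of the way to the limit. The expected change is a 3.5-fold higher number from compound 3 to compound 4 (0.54 log units; beyond the scatter). For compound 4, the estimate is 12 ug/mL, with an expected range from 3 ug/mL to 45 ug/mL.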

Compound 4, half-maximal inhibitory concentration: 3.47 ug/mL
Beside the measured number, compound 4's estimate is 3.5-fold (0.54 log units) above it, and the stated range covers the measured number.
By their numbers in this assay, from the lowest: compounds 3, 4 and 2 (each within the scatter of the next). At a limit, above all of these: compound 1.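

Within the data shown here, at this carbonyl carbon in this assay, the earlier compounds left unclear whether the loss seen with compound 1 came with any aromatic ring, and the two new close comparisons argue against that: no change at the digits printed from compound 3 to compound 4 (within the scatter), and a 1.7-fold lower number from compound 2 to compound 4 (0.24 log units; within the scatter). An unsubstituted phenyl ring on the carbonyl is therefore compatible with a number in the same range as isopropyl or the free amine, while removing the two chloro groups gives an at least 14-fold lower number from compound 1 to compound 4 (1.15 log units; beyond the scatter), so within these compounds the large difference goes with the chloro groups and not with the ring itself. Compound 1 sits at a limit of the assay, so the true size of that step is unknown: the limit of > 50 ug/mL in this assay, at which 1 of the 4 values shown sits.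

The compounds shown leave open whether a single chloro group on the phenyl ring would be enough to produce the shift, or whether both are needed. They also leave open how other groups at this carbonyl carbon would read, such as a longer alkyl chain, or a phenyl ring carrying a methoxy group or a carboxylic acid.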